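The source may report more compounds than this note shows. Statements on the series, on what has been measured and on what is new or still open speak of the compounds shown alone.

Three dichloroacetamides built on the same core were examined, each carrying a single substituent on the aromatic ring. Compound 1 `O=C(Nc1cccc(F)c1)C(Cl)Cl` carries fluoro; in a functional assay on KB cells (Homo sapiens) for antiproliferative activity, read by MTT assay, with a stated time of 72 h (on this read-out lower numbers stand for stronger inhibition and higher numbers for weaker inhibition), compound 1 is recorded as "not determined" (no result reported), so it contributes no number. Compound 2 `O=C(Nc1cccc(Br)c1)C(Cl)Cl` carries bromo, and in this assay compound 2 gives 8180 nM. Within the data shown here, compound 3 `COc1cccc(NC(=O)C(Cl)Cl)c1` carries methoxy, and in this assay compound 3 gives 57700 nM, the higher of the two numbers available; the single measured step, a 7.1-fold higher number from compound 2 to compound 3 (0.85 log units; beyond the scatter), separates it from compound 2. Compound 4 `O=C(Nc1cccc(OC(F)(F)F)c1)C(Cl)Cl` differs from compound 3 by trifluoromethyl in place of methyl on an oxygen on an aromatic ring. Among the measured compounds shown here, no measured step covers this exchange, so the bromo-to-methoxy step is the only guide, and it shows that swapping the substituent at this place can shift the number well beyond the scatter. Whether the trifluoromethyl on the oxygen brings the number back toward compound 2 or leaves it near compound 3 cannot be read from these data; a modest lowering is expected, and the expected step is a 3.8-fold lower number from compound 3 to compound 4 (0.59 log units; beyond the scatter). Compound 4 is expected to give about 15000 nM in this assay, within 4500 nM to 50000 nM.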

Compound 4, half-maximal inhibitory concentration: 7410 nM
Beside the measured number, compound 4's estimate is 2.0-fold (0.31 log units) above it; measured number inside the range.
By their numbers in this assay, from the lowest: compounds 4 and 2 (each within the scatter of the next); then compound 3.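

In this assay, the change from methoxy to trifluoromethoxy gives a 7.8-fold lower number from compound 3 to compound 4 (0.89 log units; beyond the scatter), so exchanging only the methyl on the oxygen for trifluoromethyl moves the number well beyond the scatter, even though the oxygen itself stays in place. The other new step, a 1.1-fold lower number from compound 2 to compound 4 (0.04 log units; within the scatter), lies within the scatter, so trifluoromethoxy and bromo cannot be told apart here, and methoxy alone stands apart among the three groups with numbers. Nothing available gives a reason for either step.

The compounds shown leave open what an amine, a carboxylic acid or a longer chain such as ethoxy would do in this place. They also leave open whether the same pattern would hold for trifluoromethoxy and methoxy on a different core.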